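Taking the Bromo Group off Compound 2

The source may hold more compounds than are shown below. What is called first, only, known or untested is meant among the compounds shown, and "the series" means these compounds.

In an ADME assay on HFF cells (Homo sapiens) for cytotoxicity, with a stated time of 72 h (on this read-out higher numbers stand for lower toxicity in this test and lower numbers for higher toxicity in this test), compound 1 `CC(C)(C)c1ccc(C(=O)Nc2cc(Cl)c(Br)nc2C(=O)O)cc1` gives > 50000 nM, which is a limit of the assay. Compound 2 `CC(C)(C)c1ccc(C(=O)Nc2ccc(Br)nc2C(=O)O)cc1` gives > 50000 nM, also a limit and not a number. Both compounds thus sit at the limit of > 50000 nM in this assay, at which 2 of the 2 values shown sit. For the measured compounds named here, the one measured step, hydrogen in place of chloro on an aromatic carbon, is a step that the two limits leave unreadable from compound 1 to compound 2. Compound 3 `CC(C)(C)c1ccc(C(=O)Nc2cccnc2C(=O)O)cc1` differs from compound 2 by hydrogen in place of bromo on an aromatic carbon. Going by the values given here, with only that unreadable step to go on, no shift beyond the scatter is expected in this assay, and the expected step is a step that the limit leaves unreadable from compound 2 to compound 3. Compound 3 is estimated at 60000 nM, with an expected range of 30000 nM to 120000 nM.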

Compound 3, half-maximal cytotoxic concentration: 9000 nM
Compound 3: the middle estimate sits 6.7-fold (0.82 log units) above what was measured, and the stated range ends above it.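

In this assay, the bromo group on the aromatic carbon next to the ring nitrogen proves to count: hydrogen in its place gives an at least 5.5-fold lower number from compound 2 to compound 3 (0.74 log units; beyond the scatter), and the lower number stands for higher toxicity in this test. Compound 3 is the only compound shown with a readable number, while the chloro step stayed unreadable: the limit of > 50000 nM in this assay, at which 2 of the 3 values shown sit.

As far as these compounds go, the full size of the step stays open, as compound 2 stands at a limit. Also open, from the compounds shown here alone, is whether a methyl group or an amine at this position would behave like bromo or like hydrogen.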